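The compounds below may be only part of what the source reports. "The series", "measured", "known", "first", "only" and "open" are said of these compounds alone.

In a functional assay on A549 cells (Homo sapiens) for cytotoxicity, read by MTT assay, with a stated time of 48 h (a higher number here means a weaker inhibitor, a lower number a stronger inhibitor), compound 1 (`CC1(C)CCCC2=CC=C(C=O)CC[C@]21C`) gives 138000 nM and compound 2 (`C#CC1=CC[C@@]2(C)C(=C)CCC[C@]2(C)CC1`) gives 148000 nM. Compound 3 (`C=C1CCC[C@]2(C)CCC(c3cn(-c4cccc([N+](=O)[O-])c4)nn3)=CC[C@@]12C`) stands lowest of the three at 24700 nM, beyond the scatter from both others. Compound 4 (`C=C1CCC[C@]2(C)CCC(c3cn(-c4ccc(C)cc4)nn3)=CC[C@@]12C`) has 4-methylphenyl in place of 3-nitrophenyl on an aromatic nitrogen, and the shared core is otherwise unchanged: 4-methylphenyl in place of 3-nitrophenyl on an aromatic nitrogen. Among the compounds with values here, no measured pair shows what this exchange does, so any expectation remains tentative. The expected step, a 1.2-fold higher number from compound 3 to compound 4 (0.08 log units; within the scatter), is small, with no change beyond the scatter anticipated in this assay. For compound 4 the estimated value is 30000 nM, with an expected range from 12000 nM to 70000 nM.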

Compound 4, half-maximal inhibitory concentration: 58800 nM
Estimate against measurement, compound 4: 2.0-fold (0.29 log units) below; measured number inside the range.
By their numbers in this assay, from the lowest: compound 3; then compound 4; then compounds 1 and 2 (each within the scatter of the next).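

In this assay, within the data shown here, the exchange of 3-nitrophenyl for 4-methylphenyl on the aromatic nitrogen gives a 2.4-fold higher number from compound 3 to compound 4 (0.38 log units; beyond the scatter), the first sign that the group at this position can move the number beyond the scatter, though only modestly. Because the two groups differ in both substituent and its place on the phenyl ring, this single pair cannot separate those two changes. Nothing available explains the step.

From the compounds shown here alone, it remains open what plain phenyl, or a phenyl carrying an amine or a carboxylic acid, would give on this nitrogen. Also open, going by these compounds, is how 3-methylphenyl or 4-nitrophenyl would compare.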